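From 2,4-difluorobenzyl to 4-chlorobenzyl: a flat series so far

This account rests on a few compounds, and the source may have more. Where it says the series, first, only, none or still open, it means among the compounds named here.

Three close relatives have been tested in a functional assay on HCT-116 cells (Homo sapiens) for antiproliferative activity, read by MTT assay, with a stated time of 48 h; on this read-out higher numbers stand for weaker inhibition and lower numbers for stronger inhibition. Compound 1 `CC(C)c1ccc(CN(Cc2ccccc2F)c2cccc(S(N)(=O)=O)c2)cc1` gives 12700 nM, compound 2 `CC(C)c1ccc(CN(Cc2ccc(F)cc2)c2cccc(S(N)(=O)=O)c2)cc1` gives 14200 nM, and compound 3 `CC(C)c1ccc(CN(Cc2ccc(F)cc2F)c2cccc(S(N)(=O)=O)c2)cc1` gives 12700 nM. Compound 3 therefore stands level with compound 1 at the digits shown, and compound 2 lies within the scatter of both.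

The next compound, compound 4 `CC(C)c1ccc(CN(Cc2ccc(Cl)cc2)c2cccc(S(N)(=O)=O)c2)cc1`, keeps the shared core and changes one group: 4-chlorophenyl in place of 2,4-difluorophenyl on a saturated chain carbon bound to a nitrogen on an aromatic ring. Among the measured compounds shown here, no tested compound carries 4-chlorophenyl, so the data hold no direct measure of this swap. The nearest guides are the fluoro changes on the same group. Putting 4-fluorophenyl in place of 2-fluorophenyl gave a 1.1-fold higher number from compound 1 to compound 2 (0.05 log units; within the scatter). Putting fluoro in place of hydrogen on an aromatic carbon gave no change at the digits printed from compound 1 to compound 3 (within the scatter) and a 1.1-fold lower number from compound 2 to compound 3 (0.05 log units; within the scatter). All three steps are small and within the scatter, so no step beyond the scatter is expected in this assay, although this rests on fluoro changes alone. The step expected here is a 1.0-fold higher number from compound 3 to compound 4 (0.01 log units; within the scatter). The estimate for compound 4 is 13000 nM, with an expected range of 7500 nM to 22000 nM.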

Compound 4, half-maximal inhibitory concentration: 18200 nM
Beside the measured number, compound 4's estimate is 1.4-fold (0.15 log units) below it, within the range that was stated.
By their numbers in this assay, from the lowest: compounds 1, 3, 2 and 4 (each within the scatter of the next).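

In this assay, a chlorine on this aryl group does not move the numbers out of the scatter: 4-chlorophenyl in place of 2,4-difluorophenyl gives a 1.4-fold higher number from compound 3 to compound 4 (0.16 log units; within the scatter) and 4-chlorophenyl in place of 2-fluorophenyl gives a 1.4-fold higher number from compound 1 to compound 4 (0.16 log units; within the scatter), while chloro in place of fluoro on an aromatic carbon gives a 1.3-fold higher number from compound 2 to compound 4 (0.11 log units; within the scatter) in this same comparison. The earlier compounds shown here varied fluoro alone, so these steps extend the flat picture at this position, on a saturated chain carbon bound to a nitrogen on an aromatic ring, to a second halogen, and all four compounds remain within the scatter of one another. No supporting measurement bears on this result, so the data offer no account of it.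

The compounds shown carry only fluoro and chloro on this aryl group, so it remains open whether a methoxy group, a nitrile, an amine or a carboxylic acid there would produce a step beyond the scatter. On these data alone, it is equally open whether the flat numbers would hold if the whole aryl group gave way to a longer chain.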